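The compounds below may be only part of what the source reports. "The series", "measured", "known", "first", "only" and "open" are said of these compounds alone.

Measured in a functional assay on HeLa cells (Homo sapiens) for inhibition, read by CCK-8 assay, with a stated time of 48 h; a higher number here means a weaker inhibitor, a lower number a stronger inhibitor:

- compound 1 `COc1cc(-c2cc3nccc(-c4cc(OC)c(OC)c(OC)c4)n3n2)cc(OC)c1OC`: > 10000 nM
- compound 2 `COc1cc(-c2ccnc3cc(-c4ccc(F)cc4)nn23)cc(OC)c1OC`: 5840 nM
- compound 3 `Cn1ccc2cc(-c3cc4nccc(-c5ccc(F)cc5)n4n3)ccc21`: 5210 nM

Compound 1 has the entry > 10000 nM, which is a limit of the assay and not a number. That leaves two true numbers to compare. Compound 2 at 5840 nM and compound 3 at 5210 nM lie within the usual scatter of each other, so these two cannot be told apart.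

Compound 4 `COc1cc(-c2ccnc3cc(-c4ccc(C)c(C)c4)nn23)cc(OC)c1OC` keeps the rest of compound 2 but has 3,4-dimethylphenyl in place of 4-fluorophenyl on an aromatic carbon. Within the data shown here, no measured pair here shows what a single swap does, so the best anchor is compound 2 with its 5840 nM. In this assay, the expected change is none beyond the scatter, and the estimated step of a 1.1-fold lower number from compound 2 to compound 4 (0.03 log units; within the scatter) is correspondingly small. For compound 4 the estimated value is 5500 nM, with an expected range from 1800 nM to 10000 nM.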

Compound 4, half-maximal inhibitory concentration: 241 nM
Compound 4: the middle estimate sits 23-fold (1.36 log units) above what was measured; measured number outside the range, below it.
By their numbers in this assay, from the lowest: compound 4; then compounds 3 and 2 (each within the scatter of the next). At a limit, above all of these: compound 1.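

In this assay, among these compounds, placing 3,4-dimethylphenyl where 4-fluorophenyl stood gives a 24-fold lower number from compound 2 to compound 4 (1.38 log units; beyond the scatter), the first single change in this set whose effect can be read. This place on the five-membered aromatic ring is therefore sensitive to the group it carries, even though both groups have one six-membered aromatic ring of carbon only, no hydrogen-bond donors or acceptors, and no net charge. No measured property shown here accounts for the difference.

The compounds shown leave open whether both methyl groups are needed, as neither 3-methylphenyl nor 4-methylphenyl is among them. From the compounds shown here alone, it also remains open how a phenyl ring carrying an amine or a carboxylic acid would fare at this place.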